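This account rests on a few compounds, and the source may have more. Where it says the series, first, only, none or still open, it means among the compounds named here.

Working notes on the series. Compound 2 `Cc1nc(C)c([C@H](OC(C)(C)C)C(=O)O)c(N2CCC(C)(C)CC2)c1-c1ccc(SCCc2ccc(F)cc2)cc1` is the starting point for the next change. In an ADME assay on microsomes from liver (Rattus norvegicus) for metabolic stability, read by LC-MS, tested at 0.5 uM (a lower number here means that the compound disappears faster, a higher number that the compound lasts longer), compound 2 gives > 2 h, which is a limit of the assay and not a number. Its measured neighbour, compound 1 `Cc1nc(C)c([C@H](OC(C)(C)C)C(=O)O)c(N2CCC(C)(C)CC2)c1-c1ccc(OCCc2cc(F)c(F)cc2F)cc1`, in this assay gives > 2 h, likewise a limit. Going by the values given here, the one measured step, a step that the two limits leave unreadable from compound 1 to compound 2, therefore cannot be sized; all that can be read is that (the limit of > 2 h in this assay, at which 2 of the 2 values shown sit).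

Compound 3 `Cc1nc(C)c([C@H](OC(C)(C)C)C(=O)O)c(N2CCC(C)(C)CC2)c1-c1ccc(OCCc2cccnc2)cc1` has not yet been measured in this assay. It differs from compound 2 by 2-(pyridin-3-yl)ethoxy in place of (2-(4-fluorophenyl)ethyl)sulfanyl on an aromatic carbon. Among the compounds with values here, no measured step bears on this change: the only step in hand, from compound 1 to compound 2, replaces one side chain on the same aromatic carbon by another, and both ends of it sit at the limit, so it gives no direction and no size. With both measured compounds at the limit, compound 3 is expected to sit near the limit as well, so the step that the limit leaves unreadable from compound 2 to compound 3 is expected to be none beyond the scatter. The estimate for compound 3 is 2.5 h, within 0.8 h to 6 h.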

Compound 3, half-life: 0.783 h
Beside the measured number, compound 3's estimate is 3.2-fold (0.50 log units) above it, and the stated range ends above it.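

At this position, on an aromatic carbon para to a large group, the side chain now registers in this assay: 2-(pyridin-3-yl)ethoxy in place of (2-(4-fluorophenyl)ethyl)sulfanyl gives an at least 2.5-fold lower number from compound 2 to compound 3 (0.40 log units; beyond the scatter). Compound 1 also carries an oxygen in its chain and gives > 2 h, which is a limit of the assay, so that oxygen alone does not take the number off the limit. With the oxygen kept, pyridin-3-yl in place of 2,4,5-trifluorophenyl gives an at least 2.5-fold lower number from compound 1 to compound 3 (0.40 log units; beyond the scatter), so a change of the ring at the end of the chain is enough to produce a step, and its full size stays unknown because the starting value is a limit: the limit of > 2 h in this assay, at which 2 of the 3 values shown sit.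

The compounds shown leave open whether this step follows the ring nitrogen of pyridin-3-yl or the loss of the fluorines, a question that an unsubstituted phenyl on the same ethoxy chain would separate. Also open, going by these compounds, are how pyridin-4-yl or a longer chain would read in this assay, and the step from compound 1 to compound 2, which cannot be read.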